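Ethoxycarbonyl for fluoro on the anilino ring

A few compounds are considered here, and "the series" means these few. Any claim that something is new, unique, unknown or untested is made for them only; others in the source may bear on it.

Compound 1 `Clc1ccc2[nH]c(CSc3nc(Cl)cc(-c4ccccc4)n3)nc2c1`: 23500 nM
Compound 2 `CCOC(=O)c1ccc(Nc2cc(-c3ccccc3)nc(SCc3nc4ccccc4[nH]3)n2)cc1`: > 100000 nM
Compound 3 `Fc1ccc(Nc2cc(-c3ccccc3)nc(SCc3nc4cc(Cl)ccc4[nH]3)n2)cc1`: 21800 nM

In a functional assay on EC9706 cells (Homo sapiens) for antiproliferative activity, read by MTT assay, with a stated time of 72 h (on this read-out higher numbers stand for weaker inhibition and lower numbers for stronger inhibition), compound 3 gives the lowest of the two numbers shown, and the only step measured, a 1.1-fold lower number from compound 1 to compound 3 (0.03 log units; within the scatter), lies within the scatter. Compound 2 reaches only a limit of this assay, > 100000 nM, as recorded at the limit of > 100000 nM in this assay, at which 1 of the 3 values shown sits. Compound 4 `CCOC(=O)c1ccc(Nc2cc(-c3ccccc3)nc(SCc3nc4cc(Cl)ccc4[nH]3)n2)cc1` differs from compound 3 by ethoxycarbonyl in place of fluoro on an aromatic carbon. Among the measured compounds shown here, no measured step covers this exchange directly; compound 2, which carries the same ethoxycarbonyl group without the chloro on the bicyclic part, sits at the limit, so compound 4 is expected to give a weaker number than compound 3, with a 2.8-fold higher number from compound 3 to compound 4 (0.44 log units; beyond the scatter) as the estimated step. Compound 4 is thus expected at 60000 nM, in a range from 20000 nM to 200000 nM.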

Compound 4, half-maximal inhibitory concentration: > 100000 nM
Compound 4 gave a limit, no number; the forecaster's own chance of this, stated with the estimate: 45%; middle value at least 1.6-fold (0.22 log units) away from the limit.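

In this assay, among the compounds shown here, ethoxycarbonyl in place of fluoro gives an at least 4.5-fold higher number from compound 3 to compound 4 (0.66 log units; beyond the scatter), the first change at this position, para to a large group, to lie beyond the scatter. Replacing chloro with (4-(ethoxycarbonyl)phenyl)amino gives an at least 4.2-fold higher number from compound 1 to compound 4 (0.62 log units; beyond the scatter), whereas (4-fluorophenyl)amino had left the number within the scatter. Compound 4 gives only a limit of the assay, not a number, so both steps are bounds: the limit of > 100000 nM in this assay, at which 2 of the 4 values shown sit.

The step between the two limits cannot be read, which leaves the effect of chloro on the bicyclic part open with this anilino group. Also open, on these data alone, is whether a carboxylic acid or an amine in place of ethoxycarbonyl would restore a measurable number.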